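Working notes: trifluoromethoxy in place of fluoro

The compounds below may be only part of what the source reports. "The series", "measured", "known", "first", "only" and "open" are said of these compounds alone.

Compound 1 `O=C(CCCCC(S)CCS)Nc1ccccc1`: 15.8%
Compound 2 `O=C(CCCCC(S)CCS)Nc1ccc(F)cc1`: 28.2%

For the measured compounds named here, in a functional assay on KB cells (Homo sapiens) for inhibition, read by MTT assay, with a stated time of 24 h, tested at 100 ug/mL (on this read-out higher numbers stand for more inhibition of growth at the one concentration tested and lower numbers for less inhibition of growth), compound 2 gives 28.2%, the highest of the two numbers so far, while compound 1 gives 15.8%. The next compound to be measured is compound 3 `O=C(CCCCC(S)CCS)Nc1ccc(OC(F)(F)F)cc1`, with trifluoromethoxy in place of fluoro on an aromatic carbon.

Going by the values given here, one measured step bears on this change: a number 12.4 percentage points higher from compound 1 to compound 2 (beyond the scatter). It is modest, and it concerns fluoro in place of hydrogen rather than the group now entering. Among the compounds with values here, no measured compound carries trifluoromethoxy, so the basis is thin. A further upward step of similar modest size is expected in this assay, and the estimated step is a number 11.8 percentage points higher from compound 2 to compound 3 (beyond the scatter). For compound 3 the expected value is 40%, with an estimated range of 24% to 58%.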

Compound 3, percent growth inhibition at one concentration: 73.3%
The estimate for compound 3 lay 33.3 percentage points below the measured number, and the stated range ends below it.
By their numbers in this assay, from the lowest: compound 1; then compound 2; then compound 3.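

In this assay exchanging fluoro for trifluoromethoxy gives a number 45.1 percentage points higher from compound 2 to compound 3 (beyond the scatter) as a large step, and trifluoromethoxy in place of hydrogen gives a number 57.5 percentage points higher from compound 1 to compound 3 (beyond the scatter) as another large one, whereas fluoro in place of hydrogen gave only a number 12.4 percentage points higher from compound 1 to compound 2 (beyond the scatter) as a modest step. For the compounds shown here, the group at this place, para to a large group, can therefore shift growth inhibition much further than the fluoro step alone showed, and across these three compounds the numbers rise from hydrogen through fluoro to trifluoromethoxy with no compound against that order. Nothing available here accounts for the size of the new step.

A methoxy or a trifluoromethyl group at this carbon would separate the part played by the oxygen from that of the fluorines. On these data alone, how an amine or a carboxylic acid would read at this place remains open, as does whether the large step holds at other carbons of the ring.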